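The compounds below may be only part of what the source reports. "The series", "measured", "known", "first", "only" and "open" are said of these compounds alone.

Two compounds of the series carry numbers in a functional assay on SF-539 cells (Homo sapiens) for inhibition, read by sulforhodamine B assay, with a stated time of 48 h; a lower number here means a stronger inhibitor of growth, a higher number a weaker inhibitor of growth: compound 1 `COc1cc(C)cc(-c2c(-c3ccnc(-c4ccc(C(C)=O)cc4)c3)cnn2CC#N)c1` gives 2020 nM, and compound 2 `Cc1cc(O)cc(-c2nn(CC#N)cc2-c2ccnc(-c3ccc(Oc4ccccc4)cc3)c2)c1` gives 3380 nM. Compound 1 has the lower of the two numbers, yet the gap to compound 2 lies within the scatter, so the pair reads alike. Compound 3 `COc1cc(C)cc(-c2c(-c3ccnc(-c4ccc(N(C)C)cc4)c3)cnn2CC#N)c1` differs from compound 1 by one change, (dimethylamino in place of acetyl on an aromatic carbon). Within the data shown here, no measured pair carries this change, so nothing here fixes its size; the step in this assay is expected to stay within the scatter, with no set direction. Compound 3 is expected near 2500 nM, within 800 nM to 8000 nM. That estimate implies a step of a 1.2-fold higher number from compound 1 to compound 3 (0.09 log units; within the scatter).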

Compound 3, concentration for 50% growth inhibition: 127 nM
The estimate for compound 3 lay 20-fold (1.29 log units) above the measured number; measured number outside the range, below it.
By their numbers in this assay, from the lowest: compound 3; then compounds 1 and 2 (each within the scatter of the next).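

In this assay, 4-(dimethylamino)phenyl in place of 4-acetylphenyl gives a 16-fold lower number from compound 1 to compound 3 (1.20 log units; beyond the scatter) and so places compound 3 clearly apart from compound 1, showing that this aromatic carbon, para to a large group, is sensitive to the group it carries. Both groups count 3 heavy atoms and 1 hydrogen-bond acceptor, so those counts do not separate them. Nothing available explains the step.

As far as these compounds go, whether the lower number is specific to dimethylamino remains open. An unsubstituted amine, a methoxy group or a morpholine on this carbon would test that.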